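Changing the Ring at the End of the Chain

The compounds below may be only part of what the source reports. "The series", "measured", "known", "first", "only" and "open" are said of these compounds alone.

Two measured compounds share one core and differ only in the ring at the end of a double-bonded chain. Compound 1 `COc1ccc(/C=C/C(=O)Nc2cc(C(=O)c3cc(OC)c(OC)c(OC)c3)ccc2OC)cc1` carries a 4-methoxyphenyl there; in a functional assay on DU-145 cells (Homo sapiens) for cytotoxicity, read by MTT assay, with a stated time of 72 h (on this read-out higher numbers stand for weaker inhibition and lower numbers for stronger inhibition), compound 1 gives 12800 nM. Compound 2 `C#CCOc1cccc(/C=C/C(=O)Nc2cc(C(=O)c3cc(OC)c(OC)c(OC)c3)ccc2OC)c1` carries a 3-(propargyloxy)phenyl in its place, and in this assay compound 2 gives 15800 nM. That swap, a 1.2-fold higher number from compound 1 to compound 2 (0.09 log units; within the scatter), produced no difference that can be trusted. On the two numbers seen, compound 2 lies within the scatter of compound 1, so nothing separates them.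

Compound 3 `COc1ccc(C(=O)c2cc(OC)c(OC)c(OC)c2)cc1NC(=O)/C=C/c1ccc(F)cc1` has not been measured. It alters the same position once more: 4-fluorophenyl in place of 3-(propargyloxy)phenyl on a double-bonded chain carbon bound to a double-bonded chain carbon. Among the measured compounds shown here, the only step that bears on this kind of change is a 1.2-fold higher number from compound 1 to compound 2 (0.09 log units; within the scatter), which lay within the scatter; no measured step involves a 4-fluorophenyl. A step no larger than the scatter is therefore expected in this assay, with no clear direction. The expected step is a 1.2-fold lower number from compound 2 to compound 3 (0.08 log units; within the scatter). Compound 3 is estimated at 13000 nM, with a range from 4500 nM to 40000 nM.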

Compound 3, half-maximal inhibitory concentration: 3900 nM
Compound 3: middle estimate off by 3.3-fold (0.52 log units), on the high side; measured number below the stated range.
By their numbers in this assay, from the lowest: compound 3; then compounds 1 and 2 (each within the scatter of the next).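

In this assay, the ring at the end of the chain proves able to shift the number, which the earlier swap between compound 1 and compound 2 did not show: there is a 4.1-fold lower number from compound 2 to compound 3 (0.61 log units; beyond the scatter), and also a 3.3-fold lower number from compound 1 to compound 3 (0.52 log units; beyond the scatter), so compound 3 stands apart from both, though both steps are modest. The second step is the cleaner comparison, since only fluoro in place of methoxy on an aromatic carbon separates the pair, whereas the first exchanges a 3-(propargyloxy)phenyl for a 4-fluorophenyl, so the group and its printed ring number both change. Nothing shown explains why the fluoro compound gives the lower number.

Going by these compounds, with a single fluoro compound, it remains open whether fluorine itself matters or whether losing the methoxy or propargyloxy group is enough, and a plain unsubstituted phenyl at this place would help to separate those two readings. On these data alone, it is equally open whether a chloro group or an amine on the same ring would follow compound 3 or fall back towards compound 1 and compound 2.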